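The source may report more compounds than this note shows. Statements on the series, on what has been measured and on what is new or still open speak of the compounds shown alone.

Of the compounds shown here, two sharing one core have been tested in a functional assay on HEK293 cells (Homo sapiens) for cytotoxicity; a lower number here means that less compound is tolerated, a higher number that more compound is tolerated. Compound 1 `COc1ccc([C@H]2CC(=O)N(c3ccc([S+](C)[O-])cc3)C2)cc1OC1CCCC1` gives 7510 nM there. Compound 2 `COc1ccc([C@H]2CC(=O)N(c3cccc(NCc4ccoc4)c3)C2)cc1OC1CCCC1` reaches only a limit of the assay, > 10000 nM. That value is the limit of > 10000 nM in this assay, at which 1 of the 2 values shown sits. Compound 3 `COc1ccc([C@H]2CC(=O)N(c3cccc(NS(=O)(=O)c4cccc(F)c4)c3)C2)cc1OC1CCCC1` has not yet been measured. It differs from compound 2 in one place: (3-fluorophenyl)sulfonyl in place of (furan-3-yl)methyl on a nitrogen on an aromatic ring. For the measured compounds named here, no measured pair shows what this change does, so in this assay a step of about a number no higher from compound 2 to compound 3 (the limit leaves the size open) is expected, which is none beyond the usual scatter in either direction. Compound 3 is therefore estimated at 10000 nM, with a likely range from 4000 nM to 25000 nM.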

Compound 3, half-maximal cytotoxic concentration: > 10000 nM
Compound 3 gave a limit, no number; the forecaster's own chance of this, stated with the estimate: 60%; the middle value sits exactly at the limit.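

Compound 2 and compound 3 both give a limit rather than a number, so no step can be read between them: the limit of > 10000 nM in this assay, at which 2 of the 3 values shown sit.

From the compounds shown here alone, whether (3-fluorophenyl)sulfonyl in place of (furan-3-yl)methyl shifts the value in this assay at all stays open.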